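A few compounds are considered here, and "the series" means these few. Any claim that something is new, unique, unknown or untested is made for them only; others in the source may bear on it.

Among the compounds with values here, the three compounds measured so far share one core and differ only in the aryl group on the ring nitrogen. Compound 1 `Nc1scc(CN2CCN(c3ccc([N+](=O)[O-])cc3)CC2)c1C(=O)c1ccc(Cl)cc1` gives -8.3% in a functional assay on CHO cells with adenosine receptor A1 (Homo sapiens) as the target, read by cAMP accumulation and immunoassay, with a stated time of 6 min, tested at 1 uM; on this read-out lower numbers stand for a stronger effect and higher numbers for a weaker effect at the one concentration tested; compound 2 `Nc1scc(CN2CCN(c3ccncc3)CC2)c1C(=O)c1ccc(Cl)cc1` gives -8.3%; compound 3 `Nc1scc(CN2CCN(c3ccccc3F)CC2)c1C(=O)c1ccc(Cl)cc1` gives -9.2%. All three sit within the scatter of one another: the change in the read-out was a number 0.9 percentage points lower from compound 1 to compound 3 (within the scatter) and a number 0.9 percentage points lower from compound 2 to compound 3 (within the scatter), and the exchange of the aryl group from compound 1 to compound 2 gave no change at the digits printed from compound 1 to compound 2 (within the scatter). Compound 3 therefore stands among its neighbours rather than apart from them.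

Compound 4 `Nc1scc(CN2CCN(c3c(F)cc(F)cc3F)CC2)c1C(=O)c1ccc(Cl)cc1` carries 2,4,6-trifluorophenyl in place of 2-fluorophenyl on an amine nitrogen in a ring. Within the data shown here, the three recorded steps all swap the aryl group on the same ring nitrogen and none moved the read-out beyond the scatter, and no step that adds fluorine atoms has been measured; they bear on the new step only loosely. On that basis the step to compound 4 is expected to be a number 0.2 percentage points higher from compound 3 to compound 4 (within the scatter), with no movement beyond the scatter. Compound 4 is thus estimated at -9%, within a range of -22% to 4%.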

Compound 4, a percentage reported as activity, at one concentration (the size of the read-out at that concentration, not a potency): -56%
Compound 4: the middle estimate sits 47 percentage points above what was measured, outside the stated range (below it).
By their numbers in this assay, from the lowest: compound 4; then compounds 3, 1 and 2 (each within the scatter of the next).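

In this assay the aryl group on the ring nitrogen proves able to move the read-out, which the earlier exchanges at this position had not shown: the change to 2,4,6-trifluorophenyl gave a number 46.8 percentage points lower from compound 3 to compound 4 (beyond the scatter) and, measured from the other two neighbours, a number 47.7 percentage points lower from compound 2 to compound 4 (beyond the scatter) and a number 47.7 percentage points lower from compound 1 to compound 4 (beyond the scatter). Compound 4 thus stands apart from all three, with the strongest effect of the set at the one concentration tested, and the step from 2-fluorophenyl differs in its count of fluorine atoms while the ring type and the donor and acceptor counts stay the same. Nothing available explains why this change has so large an effect.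

The compounds shown leave open whether 2,4-difluorophenyl or 2,6-difluorophenyl would already produce such a step, and whether 2,4,6-trichlorophenyl would match it. A single concentration also leaves the potency of compound 4 open.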